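From 2-Phenylethenyl to 2,3,4-Trimethoxyphenyl on the Shared Core

The source may report more compounds than this note shows. Statements on the series, on what has been measured and on what is new or still open speak of the compounds shown alone.

Compound 2 `Cc1cc(O)c(C2=NN(c3ccc(S(N)(=O)=O)cc3)C(/C=C/c3ccccc3)C2)cc1Cl` gives 44500 nM in a functional assay on T47D cells (Homo sapiens) for antiproliferative activity, with a stated time of 48 h; a lower number here means that less compound is tolerated, a higher number that more compound is tolerated. Within the data shown here, the only other compound measured, compound 1 `Cc1cc(O)c(C2=NN(c3ccc(S(N)(=O)=O)cc3)C(c3ccccc3Cl)C2)cc1Cl`, gives 82300 nM in this assay, and the two numbers lie within the scatter of each other. Among the measured compounds shown here, the single measured step is a 1.8-fold lower number from compound 1 to compound 2 (0.27 log units; within the scatter). Compound 3 `COc1ccc(C2CC(c3cc(Cl)c(C)cc3O)=NN2c2ccc(S(N)(=O)=O)cc2)c(OC)c1OC` differs from compound 2 by 2,3,4-trimethoxyphenyl in place of 2-phenylethenyl on a saturated ring carbon. For the measured compounds named here, the one known step at this same saturated ring carbon stayed within the scatter, so no change beyond the scatter is expected here. Compound 3 is estimated at 40000 nM, between 15000 nM and 110000 nM. This corresponds to an expected step of a 1.1-fold lower number from compound 2 to compound 3 (0.05 log units; within the scatter).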

Compound 3, concentration lethal to 50% of the cells: 47400 nM
Beside the measured number, compound 3's estimate is 1.2-fold (0.07 log units) below it, within the range that was stated.
By their numbers in this assay, from the lowest: compounds 2, 3 and 1 (each within the scatter of the next).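

In this assay, the saturated ring carbon takes 2,3,4-trimethoxyphenyl, with its 3 hydrogen-bond acceptors, and the number stays within the scatter of both earlier compounds (a 1.1-fold higher number from compound 2 to compound 3 (0.03 log units; within the scatter); a 1.7-fold lower number from compound 1 to compound 3 (0.24 log units; within the scatter)). The three groups tested at this carbon therefore give numbers that cannot be told apart. Nothing available explains this lack of separation. On these data alone, whether an amine or a carboxylic acid at this carbon would move the number beyond the scatter remains open. So does the effect of replacing the 4-sulfamoylphenyl group.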